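Dimethylamino for pyrrolidin-1-yl: half-life in three analogues

The source may hold more compounds than are shown below. What is called first, only, known or untested is meant among the compounds shown, and "the series" means these compounds.

Measured so far:
compound 1, `COc1ccc2[nH]c([S+]([O-])Cc3ncc(C)c(N4CCCC4)c3Cl)nc2c1`, gives 60 h in an ADME assay for pharmacokinetics, at pH 7.4; a lower number here means that the compound disappears faster, a higher number that the compound lasts longer.
compound 2, `COc1ccc2[nH]c([S+]([O-])Cc3ncc(C)c(N(C)C)c3Cl)nc2c1`, gives 432 h in this assay.
compound 3, `COc1ccc2[nH]c([S+]([O-])Cc3cc(N4CCCC4)c(Br)cn3)nc2c1`, gives 49 h in this assay.

Compound 1 and compound 2 share one core and differ in one place, (dimethylamino in place of pyrrolidin-1-yl on an aromatic carbon). That change made a 7.2-fold higher number from compound 1 to compound 2 (0.86 log units; beyond the scatter). Compound 3 carries a different core; how it differs from compound 1 is not broken down here. The values of compound 3 and compound 1 lie within the scatter of each other. Among the compounds with values here, the value of compound 2 is higher than that of compound 3, a gap beyond the scatter, but no single step connects the two.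

Compound 4, `COc1ccc2[nH]c([S+]([O-])Cc3cc(N(C)C)c(Br)cn3)nc2c1`, is not yet measured. It differs from compound 3 in one place, (dimethylamino in place of pyrrolidin-1-yl on an aromatic carbon). This is the same kind of change as from compound 1 to compound 2, not the same: in compound 4 the place is ortho to a bromo group, whereas in compound 2 it is ortho to a chloro group and ortho to a methyl group. Within the data shown here, only one measured pair shows this change, so the expected size rests on that one step alone.

For compound 4 a step of a 5.1-fold higher number from compound 3 to compound 4 (0.71 log units; beyond the scatter) is expected in this assay, because the same kind of change gave a 7.2-fold higher number from compound 1 to compound 2 (0.86 log units; beyond the scatter). The surroundings differ, so a wide range is estimated. Compound 4 is therefore estimated at 250 h in this assay, between 80 h and 700 h.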

Compound 4, half-life: 101 h
Beside the measured number, compound 4's estimate is 2.5-fold (0.39 log units) above it; the measured number falls inside the stated range.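

In this assay dimethylamino in place of pyrrolidin-1-yl gives a 2.1-fold higher number from compound 3 to compound 4 (0.31 log units; beyond the scatter) and so points the same way as on the core of compound 1, which makes two pairs in this series with the same direction of change. The size of the step does not carry over from one core to the other, and the gap between the two steps is larger than repeated measurement would account for: the same change on two cores in this assay, a 7.2-fold higher number (0.86 log units; beyond the scatter) from compound 1 to compound 2 and a 2.1-fold higher number (0.31 log units; beyond the scatter) from compound 3 to compound 4, 3.5-fold (0.54 log units) apart, beyond the scatter of two such steps. These two pairs do not show which feature of the cores goes with the larger or the smaller step: the place of the change has a bromo group as its only listed neighbour in compound 4 and both a chloro group and a methyl group in compound 2, and the two cores are not separated any further by the compounds at hand, so a step measured on one core gives the direction on the other but no reliable size.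

The compounds shown leave open whether another open-chain amine, such as diethylamino, follows dimethylamino on either core. Also open, going by these compounds, is how the step behaves on a core carrying a chloro group in place of the bromo group but no methyl group, a pair that would separate these two features.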